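Hydroxy in Place of Methoxy on a Benzoate Ester

The source may report more compounds than this note shows. Statements on the series, on what has been measured and on what is new or still open speak of the compounds shown alone.

Compound 1 `C/C=C(/C)C(=O)O[C@H]1CC(C)=C[C@@H](OC(=O)/C(C)=C\C)[C@@]2(C)CC[C@@](O)(C(C)C)[C@H]12`: 7700 nM
Compound 2 `COc1ccc(C(=O)O[C@H]2CC(C)=CC[C@@]3(C)CC[C@@](O)(C(C)C)[C@H]23)cc1`: 30500 nM

Of the compounds shown here, two have been measured in a functional assay on Jurkat cells (Homo sapiens) for cytotoxicity, read by MTT assay, with a stated time of 72 h; on this read-out lower numbers stand for stronger inhibition and higher numbers for weaker inhibition. Compound 2 stands at the highest of the two numbers; the nearest is compound 1, whose number is lower by a gap that lies beyond the scatter of repeated measurements, so compound 1 is the stronger of the two. Among the compounds with values here, no step between two measured compounds that differ in a single place has been recorded, so only the two values themselves can be compared, and they give no guide to the effect of any single change.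

Compound 3 `CC1=CC[C@@]2(C)CC[C@@](O)(C(C)C)[C@@H]2[C@@H](OC(=O)c2ccc(O)cc2)C1` has not yet been measured. Relative to compound 2 it differs in one place: hydrogen in place of methyl on an oxygen on an aromatic ring. The rest of the structure, the shared core and the ester link, is unchanged. Within the data shown here, with no measured step of this kind to lean on, the change is expected to be small, in either direction or none beyond the scatter, as the step of a 1.2-fold lower number from compound 2 to compound 3 (0.09 log units; within the scatter) is meant to show. Compound 3 is therefore estimated at 25000 nM, with a likely range from 8000 nM to 80000 nM.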

Compound 3, half-maximal inhibitory concentration: > 100000 nM
Compound 3: no number, only a limit; the forecaster's own chance of this, stated with the estimate: 15%; middle value at least 4.0-fold (0.60 log units) away from the limit.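

Within the data shown here, the first single-place step in this assay shows that this position is not indifferent: replacing methoxy with hydroxy, which turns the 4-methoxyphenyl into a 4-hydroxyphenyl, gives an at least 3.2-fold higher number from compound 2 to compound 3 (0.51 log units; beyond the scatter), a clear loss of strength even though only one methyl leaves and the shared core and ester link stay the same. Compound 3 is recorded only as a limit, > 100000 nM, and not as a number. The step therefore gives a smallest possible size and not a true one: the limit of > 100000 nM in this assay, at which 1 of the 3 values shown sits.

What the compounds shown leave open is whether the methyl on this oxygen matters specifically or whether other groups in its place could hold or improve the strength, such as a longer chain in ethoxy, an amine, or a carboxylic acid. They also give no reason for the loss, and this single step, read in one cell assay on one ester, says nothing about whether the same change would act in the same way on a different ester of the shared core.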